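Thioester series: a second benzyl arm on compound 2

A few compounds are considered here, and "the series" means these few. Any claim that something is new, unique, unknown or untested is made for them only; others in the source may bear on it.

- compound 1 `C[C@H](Cc1ccccc1)C(=O)SCCCCCCC(=O)Nc1nc(-c2ccccc2)cs1`: 3100 nM
- compound 2 `CC(Cc1ccccc1)C(=O)SCCCCCCC(=O)Nc1nc(-c2ccccc2)cs1`: 1900 nM
- compound 3 `COC(C(=O)SCCCCCCC(=O)Nc1nc(-c2ccccc2)cs1)c1ccccc1`: > 20000 nM, a limit and not a number

In a functional assay on MDA-MB-231 cells (Homo sapiens) for inhibition (a higher number here means that more compound is needed for the effect, a lower number that less compound is needed), compound 2 gives 1900 nM, and it stands together with compound 1 at the low end of the numbers available. The measured step is a 1.6-fold lower number from compound 1 to compound 2 (0.21 log units; within the scatter), and the only difference there is the fact that one of compounds 1 and 2 is drawn with a defined configuration and the other without, at the place where they differ. That step says nothing about a change of group.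

The next structure is compound 4 `O=C(CCCCCCSC(=O)C(Cc1ccccc1)Cc1ccccc1)Nc1nc(-c2ccccc2)cs1`, which differs by phenyl in place of hydrogen on a saturated chain carbon, two bonds along the chain from a carbonyl carbon. Cut one bond further out, the same difference reads methyl to benzyl.

Among the measured compounds shown here, no measured step makes this exact change. The closest evidence comes from changes to the group on the same carbonyl carbon: an at least 10-fold higher number from compound 2 to compound 3 (1.02 log units; beyond the scatter), and an at least 6.4-fold higher number from compound 1 to compound 3 (0.80 log units; beyond the scatter). Both steps replace 1-benzylethyl with methoxy(phenyl)methyl, so in this assay the number can respond strongly to a change at this group. They do not fix a direction for the new phenyl, but the only replacement measured so far moved the number upward. A modest rise is therefore expected, with wide uncertainty.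

The expected move is a 1.8-fold higher number from compound 2 to compound 4 (0.27 log units; within the scatter). For compound 4 the estimated value is 3500 nM, with an expected range of 900 nM to 14000 nM.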

Compound 4, half-maximal effective concentration: > 20000 nM
Compound 4 ended at the assay's limit (the forecaster's own chance of this, stated with the estimate: 15%); middle value at least 5.7-fold (0.75 log units) from the limit.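

Before this result, the only group change on this carbonyl carbon was 1-benzylethyl to methoxy(phenyl)methyl, which also brought in a methoxy group, so it could not show what a further phenyl does on its own. Phenyl in place of hydrogen on the saturated chain carbon, with no methoxy group involved, is enough for a large move in this assay: an at least 10-fold higher number from compound 2 to compound 4 (1.02 log units; beyond the scatter). Compound 4 gives > 20000 nM, which is a limit and not a number, so the step has a floor but no known size, and compound 3 and compound 4 cannot be placed in order: the limit of > 20000 nM in this assay, at which 2 of the 4 values shown sit.

The compounds shown leave open where along the methyl-to-benzyl change the number begins to rise, for instance with ethyl or cyclohexylmethyl in place of the methyl of compound 2. They also leave open whether the same phenyl gives the same move when an ester or an amide takes the place of the thioester.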